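Indole replacement at the thiadiazole carbon of compound 3

This account rests on a few compounds, and the source may have more. Where it says the series, first, only, none or still open, it means among the compounds named here.

The series shares one core and varies the aromatic group on the five-membered ring that carries two nitrogen and one sulfur. Compound 1 `COc1ccc2c(OCc3nnc4sc(-c5ccc[nH]5)nn34)ccnc2c1` gives 313 nM in a functional assay on EBC-1 cells (Homo sapiens) for antiproliferative activity, with a stated time of 72 h; a lower number here means a stronger inhibitor, a higher number a weaker inhibitor. Compound 2 `COc1ccc2c(OCc3nnc4sc(-c5cc[nH]c5)nn34)ccnc2c1` gives 353 nM in that assay, and the two are close: a 1.1-fold higher number from compound 1 to compound 2 (0.05 log units; within the scatter). Compound 3 `COc1ccc2c(OCc3nnc4sc(-c5cnn(C)c5)nn34)ccnc2c1` gives 88 nM in that assay and holds the lowest number of the three, with a 3.6-fold lower number from compound 1 to compound 3 (0.55 log units; beyond the scatter) and a 4.0-fold lower number from compound 2 to compound 3 (0.60 log units; beyond the scatter), both modest but beyond the scatter.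

Compound 4 `COc1ccc2c(OCc3nnc4sc(-c5cc6ccccc6n5C)nn34)ccnc2c1` is not yet measured. It differs from compound 3 by 1-methyl-1H-indol-2-yl in place of 1-methyl-1H-pyrazol-4-yl on an aromatic carbon. Within the data shown here, no measured step covers this change; the three measured steps only exchange one five-membered aromatic ring for another, and none introduces a six-membered aromatic ring of carbon only. Those steps show that the group at this position moves the number only modestly. Since compound 3 already stands lowest, a larger change of this kind is expected to give a somewhat higher number rather than a lower one, and the expected step is a 2.3-fold higher number from compound 3 to compound 4 (0.36 log units; beyond the scatter). Compound 4 is therefore estimated at 200 nM in that assay, with a range from 60 nM to 700 nM.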

Compound 4, half-maximal inhibitory concentration: 149 nM
Compound 4: the middle estimate sits 1.3-fold (0.13 log units) above what was measured, within the range that was stated.
By their numbers in this assay, from the lowest: compounds 3 and 4 (each within the scatter of the next); then compounds 1 and 2 (each within the scatter of the next).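

In this assay, the position accepts the larger 1-methyl-1H-indol-2-yl, which brings in a six-membered aromatic ring of carbon only, and a 1.7-fold higher number from compound 3 to compound 4 (0.23 log units; within the scatter) leaves compound 3 and compound 4 unseparated. The lower numbers are therefore not confined to 1-methyl-1H-pyrazol-4-yl: the indole group also stands apart from both pyrrole groups, with a 2.1-fold lower number from compound 1 to compound 4 (0.32 log units; beyond the scatter) and a 2.4-fold lower number from compound 2 to compound 4 (0.37 log units; beyond the scatter), and among the compounds shown, the two groups with a methyl on the ring nitrogen give the lower numbers, with no compound going against this. Nothing available explains why the position tolerates this change or why these groups separate as they do.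

Open is whether the methyl on the ring nitrogen matters in its own right, as the steps shown change it together with the ring, and a direct comparison of 1-methyl-1H-indol-2-yl with 1H-indol-2-yl would settle that for the indole. Also open, going by these compounds, is how far the six-membered ring of the indole can be taken, for example with an amine or a carboxylic acid attached to it.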